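The source may hold more compounds than are shown below. What is called first, only, known or untested is meant among the compounds shown, and "the series" means these compounds.

Working notes on the series around compound 1 `Cc1nn(-c2ccccc2)c2nc(-c3ccccc3)c(C#N)c(-c3ccccc3O)c12`. In an ADME assay on BJ cells (Homo sapiens) for cytotoxicity, with a stated time of 72 h (on this read-out lower numbers stand for an effect already at smaller amounts and higher numbers for an effect only at larger amounts of compound), compound 1 gives > 23000 nM, which is a limit of the assay and not a measured number. The two neighbours behave the same way. Compound 2 `CCc1ccc(-c2nc3c(c(C)nn3-c3ccccc3)c(-c3ccccc3I)c2C#N)cc1` gives in this assay > 20000 nM, again a limit. Compound 3 `CCc1ccc(-c2nc3c(c(C)nn3-c3ccccc3)c(-c3ccccc3)c2C#N)cc1` gives in this assay > 20000 nM, also a limit. For the measured compounds named here, the only step between measured compounds that differ in one place, hydrogen in place of iodo on an aromatic carbon, is a step that the two limits leave unreadable from compound 2 to compound 3. Compound 1 therefore stands where the whole set stands: the limit of > 20000 nM in this assay, at which 2 of the 3 values shown sit, and (the limit of > 23000 nM in this assay, at which 1 of the 3 values shown sits), so no ordering among the three is possible.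

The move to compound 4 `CCc1cccc(-c2nc3c(c(C)nn3-c3ccccc3)c(-c3ccccc3O)c2C#N)c1` is ethyl in place of hydrogen on an aromatic carbon, or phenyl to 3-ethylphenyl. Going by the values given here, no measured step in this assay touches this group, and the single measured step, a step that the two limits leave unreadable from compound 2 to compound 3, tells only that a change elsewhere in the molecule left the read-out at the limit. No step beyond the scatter is expected in this assay, so compound 4 is expected to stay at a limit, with a step that the limit leaves unreadable from compound 1 to compound 4 as the estimated step. The estimate for compound 4 is 25000 nM, with a range from 10000 nM to 60000 nM.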

Compound 4, half-maximal effective concentration: > 20000 nM
Compound 4: no number, only a limit; the forecaster's own chance of this, stated with the estimate: 80%; the middle value lies beyond the limit too.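

Compound 1 and compound 4 both sit at limits in this assay, so the step for ethyl in place of hydrogen on an aromatic carbon cannot be read. The compounds shown leave open at what concentration, if any, compound 1, compound 2, compound 3 and compound 4 reach a half-maximal effect, and whether any single change shifts it.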